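The source may hold more compounds than are shown below. What is called first, only, known or untested is meant among the compounds shown, and "the series" means these compounds.

Compound 1 `CCCC(=O)Nc1nc2ccc(NC(=O)CSc3ccc(Cl)cc3)cc2s1` carries a propyl group on the carbonyl carbon and, in a functional assay on U2OS cells (Homo sapiens) for antiproliferative activity, read by MTT assay, with a stated time of 72 h (a higher number here means a weaker inhibitor, a lower number a stronger inhibitor), compound 1 gives 3190 nM. Compound 2 `Cc1cc(C)cc(C(=O)Nc2nc3ccc(NC(=O)CSc4ccc(Cl)cc4)cc3s2)c1` reaches only a limit of the measurement in this assay, > 100000 nM. Among the measured compounds shown here, the step of an at least 31-fold higher number from compound 1 to compound 2 (1.49 log units; beyond the scatter) is therefore the only measured guide, and it rests on (the limit of > 100000 nM in this assay, at which 1 of the 2 values shown sits). Compound 3 `O=C(CSc1ccc(Cl)cc1)Nc1ccc2nc(NC(=O)c3ccc4ccccc4c3)sc2c1` differs from compound 2 by naphthalen-2-yl in place of 3,5-dimethylphenyl on a carbonyl carbon. Since an aromatic ring on this carbonyl carbon already sat at the limit in compound 2, compound 3 is expected to show no step beyond the scatter, a number no higher from compound 2 to compound 3 (the limit leaves the size open). The value of compound 3 is estimated at 100000 nM, between 20000 nM and 300000 nM.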

Compound 3, half-maximal inhibitory concentration: 14500 nM
Compound 3: middle estimate off by 6.9-fold (0.84 log units), on the high side; the whole stated range lies above it.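

The change to naphthalen-2-yl gives an at least 6.8-fold lower number from compound 2 to compound 3 (0.83 log units; beyond the scatter), so an aromatic ring on this carbonyl carbon does not by itself put a compound at the limit in this assay. Even so, the propyl group of compound 1 is not matched, with a 4.5-fold higher number from compound 1 to compound 3 (0.66 log units; beyond the scatter). The first of these steps has only a minimum size, as compound 2 stands at a limit: the limit of > 100000 nM in this assay, at which 1 of the 3 values shown sits.

Still open, from the compounds shown here alone, is whether a longer chain, an unsubstituted phenyl ring or a group carrying an amine on this carbonyl carbon would give a lower number than compound 1.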